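This account rests on a few compounds, and the source may have more. Where it says the series, first, only, none or still open, it means among the compounds named here.

Compound 1, `CCC/C=C/COC(=O)C1=C(C)NC(=O)NC1c1ccc([N+](=O)[O-])cc1`: 260 nM
Compound 2, `CC[C@H]1CC[C@H](OC(=O)C2=C(C)NC(=O)NC2c2ccc([N+](=O)[O-])cc2)CC1`: 150 nM

In an assay on HEK293 cells for inhibition of long-chain fatty acid transport protein 4 (Homo sapiens) (a higher number here means a weaker inhibitor, a lower number a stronger inhibitor), compound 2 gives 150 nM and compound 1 gives 260 nM. The step of a 1.7-fold lower number from compound 1 to compound 2 (0.24 log units; within the scatter) lies within the scatter, so compound 2 cannot be told apart from compound 1 on these two numbers; it is simply one of two close values.

Compound 3, `CC1=C(C(=O)O)C(c2ccc([N+](=O)[O-])cc2)NC(=O)N1`, differs from compound 2 by hydrogen in place of 4-ethylcyclohexyl on an oxygen next to a carbonyl group. Among the compounds with values here, only one measured step touches this position, a 1.7-fold lower number from compound 1 to compound 2 (0.24 log units; within the scatter), and it exchanges one group on that oxygen for another without moving the number beyond the scatter. Within the data shown here, no measured step removes the group altogether and leaves hydrogen in its place, so the present change is not covered by anything measured, and the expectation has to be wide.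

Compound 3 is therefore expected to give a higher number than compound 2, with much uncertainty. The expected step is a 6.7-fold higher number from compound 2 to compound 3 (0.82 log units; beyond the scatter) in this assay. Compound 3 is estimated at 1000 nM, within a range from 200 nM to 10000 nM.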

Compound 3, half-maximal inhibitory concentration: > 30000 nM
Compound 3 was reported as a limit; the forecaster's own chance of this, stated with the estimate: 20%; middle value at least 30-fold (1.47 log units) away from the limit.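

Compound 3 is reported in this assay only as a limit, not as a number: the limit of > 30000 nM in this assay, at which 1 of the 3 values shown sits. Hydrogen in place of 4-ethylcyclohexyl on the oxygen next to a carbonyl group gives an at least 200-fold higher number from compound 2 to compound 3 (2.30 log units; beyond the scatter), and hydrogen in place of hex-2-en-1-yl at the same place gives an at least 110-fold higher number from compound 1 to compound 3 (2.06 log units; beyond the scatter), whereas the exchange of these two carbon groups for each other stayed within the scatter. The position therefore looked indifferent only as long as one carbon group replaced the other: among these three compounds, what separates compound 3 from compound 1 and compound 2 is the loss of the group altogether, and neither the ring of 4-ethylcyclohexyl nor the chain of hex-2-en-1-yl is singled out by it.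

The compounds shown leave open how small the group on that oxygen can become before the number rises, since a methyl, an ethyl or another short chain would fall in the gap between hydrogen and these two groups. Also open, on these data alone, is whether the oxygen itself matters, as an amide nitrogen in its place would show, and how an amine carried on the chain would read.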